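Swapping Methoxy for Bromo on the Aromatic Ring

The source may hold more compounds than are shown below. What is called first, only, known or untested is meant among the compounds shown, and "the series" means these compounds.

Compound 1 `COc1ccc(-c2cnc(NC(=O)CCCCCCNC(=O)C(O)(O)C(F)(F)F)s2)cc1` gives 1000 nM
Compound 2 `COc1ccc(NC(=O)CCCCCCNC(=O)C(O)(O)C(F)(F)F)cc1` gives "not determined" (no result reported)

In a functional assay on cells (Panel NCI-60 (60 carcinoma cell lines), Homo sapiens) for inhibition, read by colorimetric assay, with a stated time of 3 days (a lower number here means a stronger inhibitor of growth, a higher number a weaker inhibitor of growth), compound 2 has no single number, so it offers no starting value. The next compound to be tested is compound 3 `O=C(CCCCCCNC(=O)C(O)(O)C(F)(F)F)Nc1ccc(Br)cc1` and it differs from compound 2 in one place. The structural change is bromo in place of methoxy on an aromatic carbon. Within the data shown here, with no measured step to go on, this single swap is expected to give only a small change, with no clear direction and perhaps none beyond the scatter. Among the measured compounds shown here, the sole anchor is compound 1 at 1000 nM in this assay but it differs from compound 2 in more than this one place, so the expectation sits somewhat higher and stays wide. For compound 3 the estimated value is 2500 nM (expected range 600 nM to 10000 nM).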

Compound 3, concentration for 50% growth inhibition: 3160 nM
Compound 3: middle estimate off by 1.3-fold (0.10 log units), on the low side, and the stated range covers the measured number.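

Compound 2 has no number in this assay so the swap from methoxy to bromo that leads to compound 3 at 3160 nM cannot be read as a step. The compounds shown leave open how these two groups compare at this place on the ring. No supporting measurement bears on the value of compound 3.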